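The source may hold more compounds than are shown below. What is called first, only, known or untested is meant among the compounds shown, and "the series" means these compounds.

Measured so far, in an assay on isolated protein with Bile acid receptor (Homo sapiens) as the target; a higher number here means that more compound is needed for the effect, a lower number that less compound is needed:

- compound 1 `COC(=O)/C=C/c1cccc(N(Cc2ccc(/C=C/c3ccccc3F)cc2)C(=O)C2CCCCC2)c1` gives 64 nM
- compound 2 `COC(=O)/C=C/c1cccc(N(Cc2ccc(/C=C/c3scnc3C)cc2)C(=O)C2CCCCC2)c1` gives 227 nM

For the measured compounds named here, compound 2 is the higher of the two numbers; the only other compound, compound 1, sits at a lower value, and the step of a 3.5-fold higher number from compound 1 to compound 2 (0.55 log units; beyond the scatter) is beyond the usual scatter. The next step goes from compound 2 to compound 3 `COC(=O)/C=C/c1cccc(N(Cc2ccc(-c3ccc(F)c(F)c3)cc2)C(=O)C2CCCCC2)c1`. Going by the values given here, the change is 3,4-difluorophenyl in place of 2-(4-methyl-1,3-thiazol-5-yl)ethenyl on an aromatic carbon, so the ring on the chain is not the only thing that changes: the double bond between that ring and the rest of the molecule leaves as well, and a fluorinated six-membered ring is attached directly to the aromatic carbon.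

Among the compounds with values here, only one measured step bears on this, and only partly: a 3.5-fold higher number from compound 1 to compound 2 (0.55 log units; beyond the scatter) shows that exchanging a fluorine-bearing carbon ring for the methyl-thiazole raised the number, so returning to a fluorine-bearing carbon ring, as in compound 3, might lower it again. Within the data shown here, no measured pair shows what removing the double-bonded chain does. The expectation for compound 3 is therefore a modest drop, a 2.1-fold lower number from compound 2 to compound 3 (0.31 log units; beyond the scatter), with a wide range, giving an estimate of 110 nM (between 30 nM and 400 nM).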

Compound 3, half-maximal effective concentration: 72 nM
For compound 3 the middle estimate is 1.5-fold (0.18 log units) above the measured one, within the range that was stated.
By their numbers in this assay, from the lowest: compounds 1 and 3 (each within the scatter of the next); then compound 2.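

In this assay, putting 3,4-difluorophenyl in place of 2-(4-methyl-1,3-thiazol-5-yl)ethenyl on this aromatic carbon gives a 3.2-fold lower number from compound 2 to compound 3 (0.50 log units; beyond the scatter) and so shows that this position does not need a double bond outside aromatic rings to reach the lower numbers seen here. The comparison with the fluorinated chain points the same way: 3,4-difluorophenyl in place of 2-(2-fluorophenyl)ethenyl gives a 1.1-fold higher number from compound 1 to compound 3 (0.05 log units; within the scatter), a difference within the scatter, so these two quite different groups cannot be told apart in this assay. No independent measurement is available to explain either result.

Both fluorine-bearing groups differ from the thiazole-bearing group in more than one feature, so the shown compounds do not separate the effect of the fluorine atoms, the ring type and the double bond. A plain phenyl ring or a 4-methyl-1,3-thiazol-5-yl group attached directly to the same aromatic carbon, or a 2-phenylethenyl group without fluorine, would help to pull these features apart.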